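From Butyl to Cycloheptyl on the Amide Nitrogen

A few compounds are considered here, and "the series" means these few. Any claim that something is new, unique, unknown or untested is made for them only; others in the source may bear on it.

Two compounds have numbers in an assay on cell membranes for binding affinity to 2-oxoglutarate receptor 1 (Rattus norvegicus), read by radioligand binding; a lower number here means a stronger inhibitor, a higher number a weaker inhibitor. Compound 1 `CCCCNC(=O)[C@H]1OC(n2cnc3c(N)ncnc32)[C@H](O)[C@@H]1O` gives 17 nM, the lower of the two numbers, but compound 2 `Nc1ncnc2c1ncn2[C@@H]1O[C@H](C(=O)NC2CCCCC2)[C@@H](O)[C@H]1O` with 18 nM sits within the scatter of it, so the two cannot be told apart. Compound 3 `Nc1ncnc2c1ncn2C1O[C@H](C(=O)NC2CCCCCC2)[C@@H](O)[C@H]1O` differs from compound 1 by cycloheptyl in place of butyl on an amide-type nitrogen. Among the compounds with values here, no measured pair covers this change, and the closeness of compound 1 and compound 2 gives no hint of a large move, so the expected step from compound 1 to compound 3 is a 1.2-fold higher number from compound 1 to compound 3 (0.07 log units; within the scatter), nothing beyond the scatter. Compound 3 is expected to give about 20 nM, between 7 nM and 60 nM.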

Compound 3, inhibition constant: 22 nM
For compound 3 the middle estimate is 1.1-fold (0.04 log units) below the measured one; measured number inside the range.
By their numbers in this assay, from the lowest: compounds 1, 2 and 3 (each within the scatter of the next).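

Replacing butyl with cycloheptyl on the amide-type nitrogen in this assay gives a 1.3-fold higher number from compound 1 to compound 3 (0.11 log units; within the scatter) and so stays within the usual scatter. At this position, an open chain of carbon and a seven-membered ring of carbon therefore cannot be told apart by their numbers, despite the added heavy atoms. Nothing available explains this result.

On these data alone, whether a chain longer than butyl would leave the number just as unmoved remains open. So does the effect of placing an amine or a carboxylic acid on the cycloheptyl ring.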